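From Isopropoxy to Methoxy on a Shared Core

The compounds below may be only part of what the source reports. "The series", "measured", "known", "first", "only" and "open" are said of these compounds alone.

compound 1 `Cc1ccc2oc(/C=C/[S+](C)[O-])cc(=O)c2c1` — in a functional assay on A549 cells (Homo sapiens) for cytotoxicity, with a stated time of 48 h (a higher number here means a weaker inhibitor, a lower number a stronger inhibitor), compound 1 gives 1700 nM
compound 2 `CCCCCOc1ccc2oc(/C=C/[S+](C)[O-])cc(=O)c2c1` — in this assay compound 2 gives 1600 nM
compound 3 `CC(C)Oc1ccc2oc(/C=C/[S+](C)[O-])cc(=O)c2c1` — in this assay compound 3 gives 1500 nM

Compound 3 stands with the lowest of the three numbers, yet the steps of a 1.1-fold lower number from compound 1 to compound 3 (0.05 log units; within the scatter) and a 1.1-fold lower number from compound 2 to compound 3 (0.03 log units; within the scatter) both lie within the scatter, so nothing separates it from compound 1 or compound 2. Compound 4 `COc1ccc2oc(/C=C/[S+](C)[O-])cc(=O)c2c1` differs from compound 3 by methyl in place of isopropyl on an oxygen on an aromatic ring. Among the measured compounds shown here, the steps that bear on this position, a 1.1-fold lower number from compound 1 to compound 2 (0.03 log units; within the scatter), a 1.1-fold lower number from compound 1 to compound 3 (0.05 log units; within the scatter) and a 1.1-fold lower number from compound 2 to compound 3 (0.03 log units; within the scatter), all stay within the scatter, though none of them places a methyl on the oxygen. The expected outcome in this assay is therefore no step beyond the scatter, no change at the digits printed from compound 3 to compound 4 (within the scatter). Compound 4 is estimated at 1500 nM, with a range from 900 nM to 2600 nM.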

Compound 4, half-maximal inhibitory concentration: 1600 nM
Compound 4: the middle estimate sits 1.1-fold (0.03 log units) below what was measured, within the range that was stated.
By their numbers in this assay, from the lowest: compounds 3, 2, 4 and 1 (each within the scatter of the next).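

Among the compounds shown here, a methyl on the oxygen, which the earlier compounds did not offer, changes little in this assay: isopropyl to methyl gives a 1.1-fold higher number from compound 3 to compound 4 (0.03 log units; within the scatter) and pentyl to methyl on the same oxygen gives no change at the digits printed from compound 2 to compound 4 (within the scatter) at this position. Methoxy in place of methyl on the aromatic carbon gives a 1.1-fold lower number from compound 1 to compound 4 (0.03 log units; within the scatter) as well. So across methyl, methoxy, isopropoxy and pentyloxy, no step at this position leaves the scatter. No evidence on mechanism accompanies these numbers. The compounds shown leave open whether an amine or a carboxylic acid at this position would give a step beyond the scatter.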